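The source may hold more compounds than are shown below. What is called first, only, known or untested is meant among the compounds shown, and "the series" means these compounds.

Four small amides share one core and differ only in the ring on the carbonyl carbon: compound 1 `O=C(Nc1cccc2cccnc12)c1cnc(Cl)cn1`, compound 2 `O=C(Nc1cccc2cccnc12)c1ccc(F)nc1`, compound 3 `O=C(Nc1cccc2cccnc12)c1cccnn1` and compound 4 `O=C(Nc1cccc2cccnc12)c1ncccn1`, which has not yet been measured. In a functional assay on PANC-1 cells (Homo sapiens) for inhibition, read by MTT assay, with a stated time of 72 h (on this read-out lower numbers stand for stronger inhibition and higher numbers for weaker inhibition), compound 1 gives 9300 nM. Compound 2 gives > 10000 nM, which is a limit of the assay and not a number. Compound 3 gives > 10000 nM, again a limit and not a number. Compound 3 therefore has no exact position and stands at the limit of > 10000 nM in this assay, at which 2 of the 3 values shown sit.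

Compound 4 has the same atoms as compound 3, joined differently, with pyrimidin-2-yl in place of pyridazin-3-yl on a carbonyl carbon. Within the data shown here, no two measured compounds differ in just one place, so the set gives no direct measure of what such a swap does. In this assay the swap is expected to cause no step beyond the usual scatter. Among the measured compounds shown here, that expectation rests on compound 1, whose 9300 nM is the only exact number in the set. It rests also on compound 2, whose > 10000 nM is a limit of the assay. It rests also on compound 3, whose > 10000 nM is a limit of the assay. The estimated change is a step that the limit leaves unreadable from compound 3 to compound 4. The assay may well report only a limit again. For compound 4 the expected value is 11000 nM, with an estimated range from 5000 nM to 25000 nM.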

Compound 4, half-maximal inhibitory concentration: > 10000 nM
Compound 4: a limit, no number; the forecaster's own chance of this, stated with the estimate: 75%; the middle value is on the limit's open side.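

Among these compounds, no step from compound 3 to compound 4 can be read in this assay, because both compounds sit at a limit of the assay and not at a number: the limit of > 10000 nM in this assay, at which 3 of the 4 values shown sit. The compounds shown leave open how strongly compound 3 and compound 4 act, and whether pyrimidin-2-yl and pyridazin-3-yl on a carbonyl carbon differ at all.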